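This account rests on a few compounds, and the source may have more. Where it says the series, first, only, none or still open, it means among the compounds named here.

Three compounds built on a shared core have been examined in an assay on isolated protein for inhibition of aldehyde dehydrogenase 1A1 (Homo sapiens); a lower number here means a stronger inhibitor, a higher number a weaker inhibitor. Compound 1 `Cn1ncc2c(=O)n(-c3ccccc3)c(COc3cccc(F)c3)nc21` gives 8200 nM in this assay. Compound 2 `Cn1ccc2c(=O)n(-c3ccccc3)c(SCc3cccc(F)c3)nc21` gives 930 nM. Compound 3 `COc1cccc(C(C)Sc2nc3c(cnn3C)c(=O)n2-c2ccccc2)c1` gives 451 nM, the lowest of the three numbers; its nearest neighbour is compound 2, whose number lies higher by an amount beyond the usual scatter, and compound 1 stands furthest from it, also well beyond the scatter. Compound 4 `COc1ccc(C(C)Sc2nc3c(cnn3C)c(=O)n2-c2ccccc2)cc1` has not yet been measured in this assay. It differs from compound 3 in a single place: 4-methoxyphenyl in place of 3-methoxyphenyl on a saturated chain carbon bound to a saturated chain carbon and a sulfur, the two having the same atoms joined differently. Going by the values given here, no pair of measured compounds shows an exchange of this kind, so the data alone give no size for the step. A rearrangement this small is expected to shift the number only modestly, in either direction, with a slight lean toward a weaker inhibitor. Compound 4 is therefore estimated at 650 nM in this assay, with a range from 250 nM to 1700 nM. The step of a 1.4-fold higher number from compound 3 to compound 4 (0.16 log units; within the scatter) is expected to be small.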

Compound 4, half-maximal inhibitory concentration: 352 nM
For compound 4 the middle estimate is 1.8-fold (0.27 log units) above the measured one, and the stated range covers the measured number.
By their numbers in this assay, from the lowest: compounds 4 and 3 (each within the scatter of the next); then compound 2; then compound 1.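

Exchanging 3-methoxyphenyl for 4-methoxyphenyl on a saturated chain carbon bound to a saturated chain carbon and a sulfur gives a 1.3-fold lower number from compound 3 to compound 4 (0.11 log units; within the scatter) in this assay. Going by these compounds alone, this is the first size available for any exchange at this place, and it shows that these two arrangements of the same atoms cannot be told apart in this assay. Nothing measured alongside these numbers bears on this result.

The compounds shown leave open whether the number would stay as flat with a phenyl ring carrying an amine or a carboxylic acid at this place, since only the two methoxyphenyl groups can be compared here. They also leave open what a longer chain on the saturated chain carbon would do.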